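Diethylamino in Place of Piperidinyl on an Inactive Anilide

The compounds below may be only part of what the source reports. "The series", "measured", "known", "first", "only" and "open" are said of these compounds alone.

Compound 1 `O=C(Nc1cc(C(F)(F)F)ccc1N1CCCCC1)c1ccccc1` was tested in a functional assay on HL-60 cells (Homo sapiens) for cytotoxicity, read by MTT assay, with a stated time of 48 h (a lower number here means a stronger inhibitor, a higher number a weaker inhibitor), where compound 1 gives "not active" (no number reported), so no concentration is reported for it. Compound 2 `O=C(Nc1cc(C(F)(F)F)ccc1N1CCCCC1)c1cccnc1Cl` likewise gives "not active" (no number reported) in this assay. Only compound 3 `O=C(Nc1cc(C(F)(F)F)ccc1NC1CCCCC1)c1ccncc1` yields a number in this assay, where compound 3 gives 59200 nM. Compound 1 thus stands without a number, alongside one further entry of the same kind. Compound 4 `CCN(CC)c1ccc(C(F)(F)F)cc1NC(=O)c1ccccc1` has not yet been measured. The change from compound 1 to compound 4 is diethylamino in place of piperidin-1-yl on an aromatic carbon. Among the compounds with values here, no step between measured compounds resembles this one, and any shift is expected to remain within the scatter. Compound 4 is estimated at 100000 nM, in a range from 30000 nM to 300000 nM, and an outcome with no reported number is considered likely.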

Compound 4, half-maximal inhibitory concentration: "not active" (no number reported)
Compound 4 has no reported number here, so the estimate cannot be set against anything.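

Compound 4, like compound 1, has no reported number, so no step can be read between them. The compounds shown leave open whether diethylamino in place of piperidin-1-yl alters activity at all. No supporting evidence bears on this result.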